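Swapping the Ester Group: What Cell Tolerance Shows

The source may hold more compounds than are shown below. What is called first, only, known or untested is meant among the compounds shown, and "the series" means these compounds.

Compound 1 `CC/C=C\C[C@H]1C(=O)C=C[C@H]1CC(=O)OCC` and compound 2 `CC/C=C\C[C@H]1C(=O)C=C[C@H]1CC(=O)Oc1ccccc1` share a core and differ only in the group on the ester oxygen. In an ADME assay on RAW264.7 cells (Mus musculus) for cytotoxicity, read by MTT assay, with a stated time of 24 h (a lower number here means that less compound is tolerated, a higher number that more compound is tolerated), compound 1 gives 146 uM and compound 2 gives 158 uM; the step of a 1.1-fold higher number from compound 1 to compound 2 (0.03 log units; within the scatter) lies within the scatter. Compound 2 therefore stands alongside compound 1, the two numbers within the scatter of each other. Compound 3 `CC/C=C\C[C@H]1C(=O)C=C[C@H]1CC(=O)OCCOCCO` differs from compound 2 by 2-(2-hydroxyethoxy)ethyl in place of phenyl on an oxygen next to a carbonyl group. Going by the values given here, only the step from compound 1 to compound 2 bears on this change, and it was within the scatter, so a further exchange at the same place in the structure gives no grounds to expect a shift beyond the scatter in this assay. The step of a 1.1-fold lower number from compound 2 to compound 3 (0.02 log units; within the scatter) is expected to be small. Compound 3 is estimated at 150 uM, within a range from 75 uM to 300 uM.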

Compound 3, half-maximal toxic concentration: 166 uM
The estimate for compound 3 lay 1.1-fold (0.04 log units) below the measured number; low and high end bracket the measured number.
By their numbers in this assay, from the lowest: compounds 1, 2 and 3 (each within the scatter of the next).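

In this assay, the exchange of phenyl, with its six-membered aromatic ring, for 2-(2-hydroxyethoxy)ethyl, with no ring, 1 hydrogen-bond donor and 2 hydrogen-bond acceptors, gives a 1.1-fold higher number from compound 2 to compound 3 (0.02 log units; within the scatter). Set against the ethyl group of compound 1, the same chain gives a 1.1-fold higher number from compound 1 to compound 3 (0.06 log units; within the scatter), so at this place, on an oxygen next to a carbonyl group, three quite different groups now stand within the scatter of one another, where the earlier pair offered only a single exchange. No measured evidence bears on the reason for this.

As far as these compounds go, whether an amine or a carboxylic acid at the end of the chain would stay within the scatter remains open. So does the outcome of an amide in place of the ester.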